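Swapping the amide heteroaryl in a weak antiproliferative series

This account rests on a few compounds, and the source may have more. Where it says the series, first, only, none or still open, it means among the compounds named here.

Measured compounds:
compound 1 `Cn1ccnc1NC(=O)c1cccc(Nc2ncc(F)c(Nc3ccc(F)cc3)n2)c1`: 10100 nM
compound 2 `O=C(Nc1ccc(C(F)(F)F)cc1)c1cccc(Nc2ncc(F)c(Nc3ccc(F)cc3)n2)c1`: > 10000 nM
compound 3 `O=C(Nc1cccc(Nc2ncc(F)c(Nc3ccc(F)cc3)n2)c1)c1ccccc1`: 37800 nM

In a functional assay on A549 cells (Homo sapiens) for antiproliferative activity, read by sulforhodamine B assay, with a stated time of 3 days (a higher number here means a weaker inhibitor of growth, a lower number a stronger inhibitor of growth), compound 1 gives 10100 nM, the lowest of the two numbers reported among the three compounds that share its core. Compound 2 reaches only the limit of this assay, reported as > 10000 nM, and the step that the limit leaves unreadable from compound 1 to compound 2 therefore cannot be read, as the evidence of the limit of > 10000 nM in this assay, at which 1 of the 3 values shown sits, makes plain. Compound 3, which reverses the amide, gives 37800 nM, a 3.7-fold higher number from compound 1 to compound 3 (0.57 log units; beyond the scatter).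

Compound 4 `O=C(Nc1nccs1)c1cccc(Nc2ncc(F)c(Nc3ccc(F)cc3)n2)c1` is not yet measured. It differs from compound 1 only in the group on the amide nitrogen: 1,3-thiazol-2-yl in place of 1-methyl-1H-imidazol-2-yl on an amide-type nitrogen. Both groups are five-membered aromatic rings carrying two hetero atoms, with no donors and two acceptors each. Going by the values given here, no measured step here exchanges one such ring for another; the two steps available change either the ring for a larger phenyl bearing trifluoromethyl or the direction of the amide, so neither speaks directly to this change. The account therefore expects compound 4 to land close to compound 1, with a step of a 1.2-fold higher number from compound 1 to compound 4 (0.07 log units; within the scatter) that need not exceed the scatter. The estimate for compound 4 in this assay is 12000 nM, with a range from 4000 nM to 40000 nM.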

Compound 4, concentration for 50% growth inhibition: > 10000 nM
Compound 4: no number, only a limit; the forecaster's own chance of this, stated with the estimate: 40%; the middle value lies beyond the limit too.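

In this assay compound 4 gives > 10000 nM, a limit of the assay and not a number. The steps to compound 4 from compound 1, compound 2 and compound 3 therefore cannot be read: the limit of > 10000 nM in this assay, at which 2 of the 4 values shown sit.

The compounds shown leave open whether 1,3-thiazol-2-yl in place of 1-methyl-1H-imidazol-2-yl on the amide-type nitrogen changes the result in this assay at all, and by how much.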